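A fluoro added to compound 3

This account rests on a few compounds, and the source may have more. Where it says the series, first, only, none or still open, it means among the compounds named here.

Compound 1 `Cc1c(Cc2c(F)cccc2F)nc(SCc2ccccc2)[nH]c1=O` reads > 70000 nM as a limit.
Compound 2 `Cc1ccc(CSc2nc(Cc3c(F)cccc3F)c(C)c(=O)[nH]2)c(C)c1` reads > 65000 nM as a limit.
Compound 3 `Cc1c(Cc2c(F)cccc2F)nc(SCC(=O)c2ccccc2)[nH]c1=O` reads 65000 nM as a plain number.

In an ADME assay on MT4 cells (Homo sapiens) for cytotoxicity, read by MTT assay (on this read-out lower numbers stand for higher toxicity in this test and higher numbers for lower toxicity in this test), compound 3 is the only one of the three with a plain number, and the other two values are limits. Compound 4 `Cc1c(Cc2c(F)cccc2F)nc(SCC(=O)c2ccc(F)cc2)[nH]c1=O` differs from it in one place by fluoro in place of hydrogen on an aromatic carbon with fluoro in place of hydrogen on an aromatic carbon. The measured steps concern the group on a saturated chain carbon bound to a sulfur. Of these, an at least 1.0-fold lower number from compound 1 to compound 3 (0.03 log units; that floor lies within the scatter) stays within the scatter, and a number no higher from compound 2 to compound 3 (the limit leaves the size open) is left open by its limit. Neither tests a fluoro, so no change beyond the scatter is expected. The expected step is a 1.1-fold lower number from compound 3 to compound 4 (0.03 log units; within the scatter) and lies within the scatter. In this assay compound 4 is estimated at 60000 nM with an expected range of 30000 nM to 100000 nM around it.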

Compound 4, half-maximal cytotoxic concentration: > 62000 nM
Compound 4: no number, only a limit; the forecaster's own chance of this, stated with the estimate: 40%; middle value at least 1.0-fold (0.01 log units) away from the limit.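

In this assay, among the compounds shown here, compound 4 gives > 62000 nM, which is a limit, so no step to it from compound 1, compound 2 or compound 3 can be read. Going by these compounds, whether the fluoro of compound 4 shifts the number at all stays open.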